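Methyl to methoxy on the aniline ring of a triazole-linked pyrimidine

The source may report more compounds than this note shows. Statements on the series, on what has been measured and on what is new or still open speak of the compounds shown alone.

Of the compounds shown here, three have been measured in a functional assay on B16-F10 cells (Mus musculus) for inhibition, read by MTT assay, with a stated time of 72 h; a lower number here means a stronger inhibitor, a higher number a weaker inhibitor. Compound 1 `COc1ccccc1Nc1nc(SCc2cn(Cc3ccccc3Cl)nn2)nc(-c2ccccc2)c1C#N` gives 7860 nM. Compound 2 `Cc1ccccc1Nc1nc(SCc2cn(Cc3ccccc3Cl)nn2)nc(-c2ccccc2)c1C#N` gives 2760 nM. Compound 3 `Cc1ccc(Nc2nc(SCc3cn(Cc4ccccc4Cl)nn3)nc(-c3ccc(C(C)C)cc3)c2C#N)cc1` gives 3530 nM.

Compound 2 and compound 1 share a core and differ in one place: methoxy in place of methyl on an aromatic carbon. That change made a step of a 2.8-fold higher number from compound 2 to compound 1 (0.45 log units; beyond the scatter), so in this assay the methoxy compound is the weaker inhibitor of the pair.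

Compound 4 `COc1ccc(Nc2nc(SCc3cn(Cc4ccccc4Cl)nn3)nc(-c3ccc(C(C)C)cc3)c2C#N)cc1` is not yet measured. It differs from compound 3 in one place: methoxy in place of methyl on an aromatic carbon. For the measured compounds named here, this is the same kind of change as the one from compound 2 to compound 1, but not the same: there the methyl sat ortho to a large group, here it sits para to a large group. The difference between the core of compound 3 and the core of compound 2 is not broken down here. Compound 3 and compound 2 give numbers that lie within the scatter of each other, so nothing can be said about their order.

Going by the values given here, only one earlier example of this change exists, and it was made at a different place on the ring. Because the earlier change gave a 2.8-fold higher number from compound 2 to compound 1 (0.45 log units; beyond the scatter), the step from compound 3 to compound 4 is expected to be a 2.0-fold higher number from compound 3 to compound 4 (0.30 log units; within the scatter), though with wide uncertainty. Compound 4 is therefore estimated to give 7000 nM in this assay, with a range from 2800 nM to 18000 nM.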

Compound 4, half-maximal inhibitory concentration: 2690 nM
Estimate against measurement, compound 4: 2.6-fold (0.42 log units) above; the whole stated range lies above it.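

Changing 4-methylphenyl to 4-methoxyphenyl on the core of compound 3 gave a 1.3-fold lower number from compound 3 to compound 4 (0.12 log units; within the scatter), so in this assay these two compounds cannot be put in order, and the clear loss seen on the other core does not reappear here. The same swap therefore did not give the same result on the two cores, so the step measured on one core could not simply be carried over to the other: the same change on two cores in this assay, a 2.8-fold higher number (0.45 log units; beyond the scatter) from compound 2 to compound 1 and a 1.3-fold lower number (0.12 log units; within the scatter) from compound 3 to compound 4, 3.7-fold (0.57 log units) apart, beyond the scatter of two such steps

This does not show why the two results differ, since the two pairs differ both in where the group sits on the ring and in the rest of the core, and two pairs cannot separate these. It also does not show that the change is harmless on every core, as it rests on one example of each kind.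

From the compounds shown here alone, it remains open whether methyl and methoxy would behave alike if each stood in the other pair's ring position with the rest of the core held fixed. Also open, going by these compounds, is how an amine, a hydroxyl or a longer chain such as ethoxy would compare with the methyl of compound 3 at that same place.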